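The compounds below may be only part of what the source reports. "The series", "measured", "known", "first", "only" and "open" are said of these compounds alone.

Measured so far in an assay on isolated protein for binding affinity to 5-hydroxytryptamine receptor 1B (Rattus norvegicus); on this read-out lower numbers stand for stronger inhibition and higher numbers for weaker inhibition:
compound 1 `Fc1cccc2c1CC2CN1CCN(c2cccc3c2OCCO3)CC1`: 316 nM
compound 2 `C1=C(CCN2CCN(c3cccc4c3OCCO4)CC2)Cc2ccccc21`: 933 nM
compound 3 `c1ccc2c(c1)CC(CCN1CCN(c3cccc4c3OCCO4)CC1)C2`: 692 nM

Compound 1 stands at the lowest number of the three in this assay; compound 3 and compound 2 both sit at higher numbers, each beyond the scatter of compound 1. Among the compounds with values here, the single measured step that changes one place is a 1.3-fold lower number from compound 2 to compound 3 (0.13 log units; within the scatter), a swap of one nine-carbon bicyclic group for another on a saturated chain carbon two bonds from the ring amine nitrogen, and it stays within the scatter.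

The next compound, compound 4 `c1ccc2c(c1)CC2CN1CCN(c2cccc3c2OCCO3)CC1`, keeps the whole core of compound 1 and differs only by hydrogen in place of fluoro on an aromatic carbon. Within the data shown here, no measured pair touches this aromatic carbon or involves a fluoro group at all, so the step from compound 2 to compound 3 does not bear on it; it merely shows that a change in the bicyclic part of this series can pass without a shift beyond the scatter. With nothing in the data pointing in either direction, the expected outcome of a 1.3-fold higher number from compound 1 to compound 4 (0.10 log units; within the scatter) is a step within the scatter, with the range widened to allow a moderate loss. Compound 4 is therefore expected to give about 400 nM in this assay, between 160 nM and 1000 nM.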

Compound 4, inhibition constant: 214 nM
Compound 4: the middle estimate sits 1.9-fold (0.27 log units) above what was measured; the range from low to high includes it.
By their numbers in this assay, from the lowest: compounds 4 and 1 (each within the scatter of the next); then compounds 3 and 2 (each within the scatter of the next).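

In this assay, the step with hydrogen in place of fluoro on an aromatic carbon, ortho to a fused ring and meta to a fused ring, is a 1.5-fold lower number from compound 1 to compound 4 (0.17 log units; within the scatter) and so gives no separation between the two compounds. The fluoro group is therefore not needed at this aromatic carbon to keep the read-out of the core of compound 1 within the scatter. The earlier step concerned only the bicyclic group on the chain and said nothing about this place, whereas this pair reads the aromatic carbon directly, though no accompanying measurement offers any explanation of the result.

Hydrogen and fluoro are the only two groups seen on this aromatic carbon, so it remains open how chloro, methoxy or an amine there would read in this assay, and whether any of them would move the number beyond the scatter. Also open, from the compounds shown here alone, is whether hydrogen and fluoro would stay this close on the bicyclic groups of compound 2 and compound 3, or with a longer chain leading to the ring amine nitrogen.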